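A few compounds are considered here, and "the series" means these few. Any claim that something is new, unique, unknown or untested is made for them only; others in the source may bear on it.

Compound 2 `COC(=O)[C@@H]1N=C(SC(C)C)[C@H]2C(=O)N(c3ccccc3)C(=O)[C@H]21` gives 89% in a functional assay for inhibition, tested at 100 uM (a higher number here means more inhibition at the concentration tested (going by the name of the read-out), a lower number less inhibition), and stands alongside compound 1 `CCCCSC1=N[C@@H](C(=O)OC)[C@@H]2C(=O)N(c3ccccc3)C(=O)[C@H]12`, which gives 82%; the step of a number 7 percentage points higher from compound 1 to compound 2 (within the scatter) lies within the scatter. Compound 3 `COC(=O)[C@@H]1N=C(SCc2ccccc2)[C@H]2C(=O)N(c3ccccc3)C(=O)[C@H]21` differs from compound 2 by benzyl in place of isopropyl on a sulfur. Within the data shown here, only one measured step bears on this change, the swap of one chain for another on the same sulfur, and it stayed within the scatter; no measured compound carries a benzyl there. The expectation for compound 3 is therefore 85%, with a range of 68% to 96%, the expected step of a number 4 percentage points lower from compound 2 to compound 3 (within the scatter) staying within the scatter.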

Compound 3, a percentage reported as inhibition, at one concentration (the size of the read-out at that concentration, not a potency): 98%
The estimate for compound 3 lay 13 percentage points below the measured number, and the stated range ends below it.
By their numbers in this assay, from the lowest: compounds 1, 2 and 3 (each within the scatter of the next, the first and the last beyond it).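

In this assay, among these compounds, benzyl on this sulfur, the first group here to carry an aromatic ring, reads the same as isopropyl within the scatter (a number 9 percentage points higher from compound 2 to compound 3 (within the scatter)). Set against the butyl chain, however, it gives the only step beyond the scatter in this small series (a number 16 percentage points higher from compound 1 to compound 3 (beyond the scatter)), so the group on this sulfur can shift the read-out, though only modestly. Nothing measured here explains this result.

The compounds shown leave open how an amine or a carboxylic acid on this sulfur would read. They also leave open whether a substituted benzyl would hold the number seen with the plain one.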